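From Chloro to Bromo on Compound 1

The compounds below may be only part of what the source reports. "The series", "measured", "known", "first", "only" and "open" are said of these compounds alone.

For the measured compounds named here, in a functional assay on MCF7 cells (Homo sapiens) for inhibition, read by MTT assay, with a stated time of 48 h (a higher number here means a weaker inhibitor, a lower number a stronger inhibitor), only two compounds have numbers so far. Compound 1 (`Clc1ccc(-c2ccnc3c2c(-c2ccccc2)nn3-c2ccccc2)cc1`) gives 61100 nM, the higher of the two and so the weaker inhibitor. Compound 2 (`N#Cc1c(-c2ccc(Cl)cc2)nc2c(c(-c3ccccc3)nn2-c2ccccc2)c1-c1ccc(N2CCCCC2)cc1`) gives 10600 nM, a lower number by a margin beyond the usual scatter. These two differ in more than one place, so their gap says nothing about any single change.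

Next comes compound 3 (`Brc1ccc(-c2ccnc3c2c(-c2ccccc2)nn3-c2ccccc2)cc1`), which differs from compound 1 by bromo in place of chloro on an aromatic carbon. Going by the values given here, no measured pair shows this exchange, so the expectation is a step no larger than the scatter, with no direction favoured. The expected change is a 1.1-fold lower number from compound 1 to compound 3 (0.05 log units; within the scatter). In this assay compound 3 is estimated at 55000 nM, with an expected range of 25000 nM to 110000 nM.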

Compound 3, half-maximal inhibitory concentration: 13300 nM
Compound 3: middle estimate off by 4.1-fold (0.62 log units), on the high side; measured number below the stated range.
By their numbers in this assay, from the lowest: compounds 2 and 3 (each within the scatter of the next); then compound 1.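

For the compounds shown here, exchanging chloro for bromo on an aromatic carbon, para to a large group, gives a 4.6-fold lower number from compound 1 to compound 3 (0.66 log units; beyond the scatter) in this assay and is the first single-place step available in this set. It shows that this position responds to the identity of the halogen, even though one heavy atom simply replaces another and no ring, hydrogen-bond donor, hydrogen-bond acceptor or net charge enters or leaves. No supporting evidence is available to explain the size or direction of this step.

The compounds shown leave open whether the same exchange would produce a similar step in compound 2, which also carries a 4-chlorophenyl group. They also leave open how fluoro, iodo, methoxy or an amine at this position would compare with chloro and bromo.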